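Chloro for methyl on the aryl ring: second occurrence

The compounds below may be only part of what the source reports. "The series", "measured", "known", "first", "only" and "open" are said of these compounds alone.

Of the compounds shown here, three on a shared core have been measured in an assay on isolated protein for inhibition of vitamin D3 receptor (Homo sapiens); on this read-out lower numbers stand for stronger inhibition and higher numbers for weaker inhibition. Compound 1 `Cc1ccc(-c2csc(=N)n2CC(=O)N2CCN(c3ccccc3)CC2)cc1` gives 1030 nM. Compound 3 `N=c1scc(-c2ccc(Cl)cc2)n1CC(=O)N1CCN(c2ccccc2)CC1` gives 3070 nM; the step of a 3.0-fold higher number from compound 1 to compound 3 (0.47 log units; beyond the scatter) is chloro in place of methyl on an aromatic carbon. Compound 2 `Cc1ccc(-c2csc(=N)n2CC(=O)N2CCOCC2)cc1` gives 13700 nM, the highest of the three numbers. The difference between the core of compound 1 and the core of compound 2 is not broken down here. Compound 4 `N=c1scc(-c2ccc(Cl)cc2)n1CC(=O)N1CCOCC1` is not yet measured; it differs from compound 2 by chloro in place of methyl on an aromatic carbon, the same change seen between compound 1 and compound 3, at the same place. Within the data shown here, the earlier step of a 3.0-fold higher number from compound 1 to compound 3 (0.47 log units; beyond the scatter) is the only guide, and it was modest and beyond the scatter. In this assay a step of a 3.0-fold higher number from compound 2 to compound 4 (0.48 log units; beyond the scatter) is expected. Compound 4 is therefore estimated at 41000 nM, with a range from 15000 nM to 110000 nM.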

Compound 4, inhibition constant: 4130 nM
For compound 4 the middle estimate is 9.9-fold (1.00 log units) above the measured one, and the stated range ends above it.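

In this assay the change from 4-methylphenyl to 4-chlorophenyl gives a 3.3-fold lower number from compound 2 to compound 4 (0.52 log units; beyond the scatter), so the earlier step does not carry over to the core of compound 2. The two steps run in opposite directions: the same change on two cores in this assay, a 3.0-fold higher number (0.47 log units; beyond the scatter) from compound 1 to compound 3 and a 3.3-fold lower number (0.52 log units; beyond the scatter) from compound 2 to compound 4, 9.9-fold (1.00 log units) apart, beyond the scatter of two such steps. This shows that, across these two pairs, the outcome of the change differs with the core; it does not show which part of the core is responsible, and two pairs set no rule for other cores.

Open, from the compounds shown here alone, is whether a fluoro or a methoxy group at the same place would also separate the two cores. Also open, going by these compounds, is whether a core with a benzyl group in place of the phenyl of compound 1 would follow compound 1 or compound 2.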